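Selenium-substituted bis-acyl isoselenourea series: cytotoxicity notes

The source may hold more compounds than are shown below. What is called first, only, known or untested is meant among the compounds shown, and "the series" means these compounds.

Measured compounds:
compound 1 `CS/C(=N\C(=O)c1cc(-c2ccccc2)nc2ccccc12)NC(=O)c1cc(-c2ccccc2)nc2ccccc12`
compound 2 `C[Se]/C(=N\C(=O)c1sccc1Cl)NC(=O)c1sccc1Cl`
compound 3 `C[Se]/C(=N\C(=O)c1cnc2ccccc2c1)NC(=O)c1cnc2ccccc2c1`

In a functional assay on K562 cells (Homo sapiens) for cytotoxicity, read by MTT assay, with a stated time of 72 h (on this read-out lower numbers stand for higher toxicity in this test and higher numbers for lower toxicity in this test), compound 3 gives 74800 nM. Compound 2 gives 90000 nM in this assay. For compound 1 this assay reports only a limit, > 100000 nM. Compound 3 thus holds the lowest of the two numbers, but its gap to compound 2 lies within the scatter, and one value stands at a limit, (the limit of > 100000 nM in this assay, at which 1 of the 3 values shown sits).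

Compound 4 `O=C(/N=C(/NC(=O)c1cnc2ccccc2c1)[Se]Cc1ccccc1)c1cnc2ccccc2c1` is not yet measured. It differs from compound 3 by phenyl in place of hydrogen on a saturated chain carbon bound to a selenium atom. Among the measured compounds shown here, no step between measured compounds covers this kind of change, so the expected step from compound 3 to compound 4 is set small, a 1.5-fold lower number from compound 3 to compound 4 (0.17 log units; within the scatter), towards a somewhat lower number. Compound 4 is therefore estimated at 50000 nM, with a range from 15000 nM to 150000 nM.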

Compound 4, concentration lethal to 50% of the cells: > 100000 nM
Compound 4: only a limit was reported; the forecaster's own chance of this, stated with the estimate: 25%; middle value at least 2.0-fold (0.30 log units) from the limit.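

In this assay, phenyl in place of hydrogen on a saturated chain carbon bound to a selenium atom gives an at least 1.3-fold higher number from compound 3 to compound 4 (0.12 log units; that floor lies within the scatter). As far as these compounds go, compound 4 gives > 100000 nM, which is a limit, so the true size of this step stays unknown and benzyl shows no gain in toxicity over methyl. The series now sits heavily at the edge of the read-out: the limit of > 100000 nM in this assay, at which 2 of the 4 values shown sit.

Open, from the compounds shown here alone, is whether a longer chain such as propyl in this place, or a benzyl carrying an amine, gives a number short of the limit. Also open, going by these compounds, is what sulfur in place of selenium does on the core of compound 3.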